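The compounds below may be only part of what the source reports. "The series", "measured", "known", "first", "only" and "open" are said of these compounds alone.

Three compounds share one core and differ only in the aryl group attached to it. Compound 1 `COC(=O)c1sc2cc(-c3ccc(F)nc3)cnc2c1N` has "not determined" (no result reported) in a functional assay on NCI-H460 cells (Homo sapiens) for inhibition, read by sulforhodamine B assay, with a stated time of 48 h; on this read-out higher numbers stand for weaker inhibition of growth and lower numbers for stronger inhibition of growth. Compound 2 `COC(=O)c1sc2cc(-c3ccc(OC)cc3)cnc2c1N` in this assay reaches only a limit of the assay, > 150000 nM, and not a number. Within the data shown here, compound 3 `COC(=O)c1sc2cc(-c3ccccc3N)cnc2c1N` gives 3800 nM in this assay, and this is the only number in the set. Among the measured compounds shown here, the one other value shown sits at the limit of > 150000 nM in this assay, at which 1 of the 3 values shown sits, and the remaining entry has no result at all. Compound 4 `COC(=O)c1sc2cc(-c3ccc(N)cc3)cnc2c1N` is the compound yet to be measured. It differs from compound 3 in one place: 4-aminophenyl in place of 2-aminophenyl on an aromatic carbon, with the same atoms joined differently. For the measured compounds named here, no step between measured compounds is available, so the size of this change is open, and whatever is said about it rests on the position of compound 3 alone among the values shown. A modest weakening is expected for compound 4, an estimated step of a 3.2-fold higher number from compound 3 to compound 4 (0.50 log units; beyond the scatter) in this assay, beyond the usual scatter but not large. Compound 4 is expected to give about 12000 nM in this assay, within a range from 3000 nM to 60000 nM.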

Compound 4, concentration for 50% growth inhibition: 37100 nM
For compound 4 the middle estimate is 3.1-fold (0.49 log units) below the measured one; the range from low to high includes it.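

In this assay, 4-aminophenyl in place of 2-aminophenyl, with the same atoms joined differently, gives a 9.8-fold higher number from compound 3 to compound 4 (0.99 log units; beyond the scatter), so the place of the amino group on the aryl ring matters for growth inhibition, and of these two compounds the one with 2-aminophenyl inhibits growth more strongly. Amino in place of methoxy gives an at least 4.0-fold lower number from compound 2 to compound 4 (0.60 log units; beyond the scatter), which shows that the group itself also counts, and that an amino group keeps measurable inhibition even in the weaker of the two arrangements. Compound 2 gives only a limit of the assay and not a number, which is why the size of that second step stays open-ended: the limit of > 150000 nM in this assay, at which 1 of the 4 values shown sits.

The compounds shown leave open whether the gain seen with 2-aminophenyl depends on the amino group itself, since a hydroxyl or a methylamino group in its place would be needed to tell. They also do not show whether the pattern holds when the methyl ester of the shared core gives way to a carboxylic acid or an amide.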